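This account rests on a few compounds, and the source may have more. Where it says the series, first, only, none or still open, it means among the compounds named here.

Measured so far in a functional assay on the whole organism (artery, strain albino) with Rattus norvegicus as the target, with a stated time of 240 min, at a dose of 10 mg/kg by the oral route; a lower number here means less inhibition, a higher number more inhibition at the dose given (going by the name of the read-out):
compound 1 `CC1=C(C(=O)Nc2ccc(F)cc2)C(c2ccc([N+](=O)[O-])cc2)N=C(SCc2ccccc2)N1`, 32.3%;
compound 2 `CC1=C(C(=O)Nc2ccc(F)cc2)C(c2ccc([N+](=O)[O-])cc2)N=C(SCc2ccccc2Cl)N1`, 15.9%.

Compound 2 stands lowest of these two numbers; its nearest neighbour is compound 1, and the single step shown, a number 16.4 percentage points lower from compound 1 to compound 2 (beyond the scatter), lies beyond the scatter. Compound 3 `CC1=C(C(=O)Nc2ccc(F)cc2)C(c2ccc([N+](=O)[O-])cc2)N=C(SCc2cccc(Cl)c2)N1` differs from compound 2 by 3-chlorophenyl in place of 2-chlorophenyl on a saturated chain carbon bound to a sulfur. Within the data shown here, no measured step moves a chloro group without adding or removing atoms, so the step from compound 1 to compound 2 bears on this only loosely. The change is therefore expected to give a number 4.1 percentage points higher from compound 2 to compound 3 (within the scatter) in this assay, within the scatter. Compound 3 is estimated at 20%, between 5% and 38%.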

Compound 3, a percentage reported as inhibition, in the whole organism at one dose (the size of the read-out at that dose, not a potency): 15.9%
Estimate against measurement, compound 3: 4.1 percentage points above; measured number inside the range.
By their numbers in this assay, from the lowest: compounds 2 and 3 (each within the scatter of the next); then compound 1.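

In this assay, putting 3-chlorophenyl in place of 2-chlorophenyl on this saturated chain carbon bound to a sulfur gives no change at the digits printed from compound 2 to compound 3 (within the scatter). Adding chloro to the unsubstituted phenyl ring in this new form gives a number 16.4 percentage points lower from compound 1 to compound 3 (beyond the scatter), so among these three compounds, having a chloro group matters, while these two chloro placements cannot be told apart. Nothing measured here explains this result. Still open, on these data alone, is whether a different group on this ring, such as methoxy or an amine, would give the same number as chloro.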